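The source may hold more compounds than are shown below. What is called first, only, known or untested is meant among the compounds shown, and "the series" means these compounds.

Measured so far:
- compound 1 `O=C(NC[C@H](NS(=O)(=O)c1ccc(O)cc1)C(=O)O)c1ccc(N2CCC(NC3=NCCCN3)CC2)c(F)c1`: 100 ug/mL
- compound 2 `O=C(NC[C@H](NS(=O)(=O)c1ccccc1)C(=O)O)c1ccc(N2CCC[C@H](NC3=NCCCN3)C2)cc1`: 3500 ug/mL
- compound 3 `O=C(NC[C@H](NS(=O)(=O)c1ccccc1)C(=O)O)c1ccc(N2CCC(NC3=NCCCN3)CC2)cc1`: < 100 ug/mL

In a physicochemical assay for solubility (on this read-out lower numbers stand for lower solubility and higher numbers for higher solubility), compound 3 stands at the limit of < 100 ug/mL in this assay, at which 1 of the 3 values shown sits, so its place is a limit and not a number.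

Compound 4 `O=C(NC[C@H](NS(=O)(=O)c1ccccc1)C(=O)O)c1ccc(N2CCC(NC3=NCCCN3)CC2)c(F)c1` follows from compound 3 by one change, fluoro in place of hydrogen on an aromatic carbon. The fluoro sits on an aromatic carbon of a six-membered aromatic ring of carbon only, ortho to a large group and meta to a large group.

Within the data shown here, no measured pair differs in one place, so the size of this change has no direct precedent. In this assay no step beyond the usual scatter is expected, in either direction. The expected step is a step that the limit leaves unreadable from compound 3 to compound 4. The expectation also leans on compound 1 at 100 ug/mL, while compound 2 at 3500 ug/mL stands far from both. Compound 4 may well report only a limit too. For compound 4 the estimate is 80 ug/mL, with an expected range of 30 ug/mL to 300 ug/mL.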

Compound 4, solubility: 600 ug/mL
Beside the measured number, compound 4's estimate is 7.5-fold (0.88 log units) below it, outside the stated range (above it).
By their numbers in this assay, from the lowest: compound 1; then compound 4; then compound 2.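

In this assay, fluoro in place of hydrogen on an aromatic carbon, ortho to a large group and meta to a large group, gives an at least 6.0-fold higher number from compound 3 to compound 4 (0.77 log units; beyond the scatter), so this place can carry a step beyond the scatter. The value of compound 3 is a limit and not a number, which makes this step a floor and not a full size: the limit of < 100 ug/mL in this assay, at which 1 of the 4 values shown sits. With fluoro present in both compounds, hydrogen in place of hydroxy on an aromatic carbon gives a 6.0-fold higher number from compound 1 to compound 4 (0.78 log units; beyond the scatter), so a second place in the series also shows a step beyond the scatter.

Going by these compounds, whether chloro or methoxy at the fluoro place would give a step of like size remains open. Also open, on these data alone, is whether fluoro at this place would give a comparable step on the core of compound 2.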